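From Methyl to Hydroxy on Compound 1

The source may hold more compounds than are shown below. What is called first, only, known or untested is meant among the compounds shown, and "the series" means these compounds.

In a functional assay on PC-3 cells (Homo sapiens) for inhibition, read by sulforhodamine B assay (a lower number here means a stronger inhibitor of growth, a higher number a weaker inhibitor of growth), compound 1 (`Cc1ccc2[nH]c(-c3ccc(-c4ccc(-c5ccc(N(C)C)cc5)cc4)cc3)nc2c1`) gives 8120 nM as the second highest of three numbers. Compound 2 (`Cc1ccc2[nH]c(-c3ccc(-c4ccc(-c5cccc(Cl)c5)cc4)cc3)nc2c1`) gives 2670 nM and lies lower, while compound 3 (`COc1ccc(-c2ccc(-c3ccc(-c4nc5ccccc5[nH]4)cc3)cc2)cc1`) gives 100000 nM and lies highest. Compound 4 (`CN(C)c1ccc(-c2ccc(-c3ccc(-c4nc5c(O)cccc5[nH]4)cc3)cc2)cc1`) is not yet measured and differs from compound 1 by one change: 4-hydroxy-1H-benzimidazol-2-yl in place of 5-methyl-1H-benzimidazol-2-yl on an aromatic carbon with 4-hydroxy-1H-benzimidazol-2-yl in place of 5-methyl-1H-benzimidazol-2-yl. Among the measured compounds shown here, the one measured single change (a 3.0-fold lower number from compound 1 to compound 2 (0.48 log units; beyond the scatter)) is modest and concerns a different group, so it offers only a rough size and no direction. No step beyond the scatter is therefore expected, and the estimated move is a 1.2-fold higher number from compound 1 to compound 4 (0.09 log units; within the scatter) in size. For compound 4 the expected value is 10000 nM with an estimated range from 2500 nM to 50000 nM around it.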

Compound 4, concentration for 50% growth inhibition: 8420 nM
Compound 4: the middle estimate sits 1.2-fold (0.07 log units) above what was measured; measured number inside the range.
By their numbers in this assay, from the lowest: compound 2; then compounds 1 and 4 (each within the scatter of the next); then compound 3.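

In this assay, 4-hydroxy-1H-benzimidazol-2-yl in place of 5-methyl-1H-benzimidazol-2-yl gives a 1.0-fold higher number from compound 1 to compound 4 (0.02 log units; within the scatter) and so the two groups cannot be told apart in this setting. Unlike the earlier step at the 4-(dimethylamino)phenyl end, this one concerns the benzimidazole itself, and it moves the hydroxy and the methyl together. Nothing at hand accounts for this result.

The compounds shown do not separate the loss of the methyl from the gain of the hydroxy. They also leave open whether an amine or a carboxylic acid on this ring would behave alike.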